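Methyl for Methoxy on a Shared Amide Core

A few compounds are considered here, and "the series" means these few. Any claim that something is new, unique, unknown or untested is made for them only; others in the source may bear on it.

Compound 1, `COc1ccccc1-c1cnc(NC(=O)c2ccc(F)cc2)n1C`: in a toxicity assay on THP-1 cells (Homo sapiens) for inhibition (a higher number here means that more compound is tolerated, a lower number that less compound is tolerated), compound 1 gives > 100000 nM, a limit of the assay.
Compound 2, `COc1ccc(C(=O)Nc2ncc(-c3ccc(OC)cc3)n2C)cc1`: in this assay compound 2 gives > 100000 nM, also a limit of the assay.

Within the data shown here, compound 2 therefore stands at a limit rather than at a number, and the same holds for the only other measured compound, as both sit at the limit of > 100000 nM in this assay, at which 2 of the 2 values shown sit. Compound 3, `COc1ccc(-c2cnc(NC(=O)c3ccc(C)cc3)n2C)cc1`, has not yet been measured. It differs from compound 2 in one place: methyl in place of methoxy on an aromatic carbon. Among the measured compounds shown here, no step between two measured compounds is available to show how far such a change moves the read-out. With both measured values resting at the limit, no step beyond the usual scatter is expected in this assay across this change. The estimated step is a step that the limit leaves unreadable from compound 2 to compound 3. Compound 3 is estimated at 150000 nM, within a range from 60000 nM to 400000 nM, and is expected most likely to be reported again as a limit.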

Compound 3, half-maximal cytotoxic concentration: > 100000 nM
Compound 3 was reported as a limit (the forecaster's own chance of this, stated with the estimate: 85%); the middle value is on the limit's open side.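

No step can be read from compound 2 to compound 3, because both values are limits and not numbers: the limit of > 100000 nM in this assay, at which 3 of the 3 values shown sit.

The compounds shown leave open how far methyl in place of methoxy moves the read-out in this assay, and which change, if any, would bring a value off this limit.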